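From oxan-4-yl to 1-methylpiperidin-4-yl: a clearance estimate

The source may report more compounds than this note shows. Statements on the series, on what has been measured and on what is new or still open speak of the compounds shown alone.

Of the compounds shown here, three carrying the oxan-4-yl group have been measured in an ADME assay on microsomes from liver (Homo sapiens) for metabolic stability; a higher number here means faster removal of the compound, a lower number slower removal. There, compound 1 `Cc1cc2nnccc2cc1Nc1ncc2c(n1)n(C1CCOCC1)c(=O)n2C` gives 14 mL.min-1.g-1, the higher of the two exact numbers obtained so far. The other exact number comes from compound 3 `Cc1cc2nccnc2cc1Nc1ncc2c(n1)n(C1CCOCC1)c(=O)n2C`, which gives 6.9 mL.min-1.g-1, a lower number by a gap just beyond the usual scatter. Compound 2 `Cc1cc2ncncc2cc1Nc1ncc2c(n1)n(C1CCOCC1)c(=O)n2C` gives > 200 mL.min-1.g-1, which is a limit of the assay and not a number.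

The next step starts from compound 1 and leads to compound 4 `Cc1cc2nnccc2cc1Nc1ncc2c(n1)n(C1CCN(C)CC1)c(=O)n2C`. The change is 1-methylpiperidin-4-yl in place of oxan-4-yl on an aromatic nitrogen, with the rest of the core of compound 1 unchanged. For the measured compounds named here, no measured pair shows what this exchange does in this assay, so the forecast rests on the starting point of compound 1 at 14 mL.min-1.g-1 and on the structural change alone, and it is uncertain. A modest rise in clearance is expected, with the estimated step being a 2.1-fold higher number from compound 1 to compound 4 (0.33 log units; beyond the scatter). For compound 4 the expected value is 30 mL.min-1.g-1, with an estimated range from 11 mL.min-1.g-1 to 80 mL.min-1.g-1.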

Compound 4, intrinsic clearance in microsomes in the Homo sapiens assay: 17 mL.min-1.g-1
Compound 4: the middle estimate sits 1.8-fold (0.25 log units) above what was measured; the range from low to high includes it.
By their numbers in the Homo sapiens assay, from the lowest: compound 3; then compounds 1 and 4 (each within the scatter of the next). At a limit, above all of these: compound 2.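

In the Homo sapiens assay, putting 1-methylpiperidin-4-yl in place of oxan-4-yl on an aromatic nitrogen gives a 1.2-fold higher number from compound 1 to compound 4 (0.08 log units; within the scatter), so this exchange at this position, with the rest of the core of compound 1 unchanged, brings no clear shift in clearance. The same pair separates clearly in a physicochemical assay for lipophilicity, read by HPLC, using the shake flask method, measured as octanol-water partition, at pH 7.4 (a lower number here means a more polar compound, a higher number a more lipophilic compound), where compound 1 gives 2.2 and compound 4 gives 1.2 as the pair moves apart: the measured distribution coefficient of compound 1, 2.2, and of compound 4, 1.2, a number 1.00 log units lower (beyond the scatter) Across this one pair, then, a fall in the distribution coefficient beyond the scatter comes with no matching shift in clearance in the Homo sapiens assay, although a single pair cannot show whether that holds for other compounds.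

In the Homo sapiens assay compound 2 gives > 200 mL.min-1.g-1, which is a limit of the assay and not a number, so the compounds shown leave open whether the same exchange would bring its clearance into a measurable range. Also open, going by these compounds, are whether the exchange behaves the same way starting from compound 3, and whether a piperidin-4-yl group without the methyl, a cyclohexyl ring or an open alkyl chain at this position would give the same picture in both assays.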